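One added methyl on the chain of compound 2

A few compounds are considered here, and "the series" means these few. Any claim that something is new, unique, unknown or untested is made for them only; others in the source may bear on it.

- Compound 1 `CCN(CC)CCNC(=O)C1CC(C(CC)(CC)c2ccc(C#CC(O)C3CCC3)c(C)c2)=CN1CC` gives 1280 nM in a functional assay on MCF7 cells (Homo sapiens) for antiproliferative activity, read by MTT assay, with a stated time of 24 h; a higher number here means a weaker inhibitor, a lower number a stronger inhibitor
- Compound 2 `CCN(CC)CCNC(=O)C1CC=C(C(CC)(CC)c2ccc(C#CC(C)(C)O)c(C)c2)N1CC` gives 1490 nM in this assay

For the measured compounds named here, compound 2 and compound 1 lie within the usual scatter of each other, so compound 2 does not stand apart from the only other measured compound. Compound 3 `CCN(CC)CCNC(=O)C1CC=C(C(CC)(CC)c2ccc(C#CC(C)(O)CC)c(C)c2)N1CC` has not yet been measured. It follows from compound 2 by one change, (methyl in place of hydrogen on a saturated chain carbon, two bonds along the chain from an oxygen on a saturated carbon and a triple-bonded carbon), which places methyl in place of hydrogen on a saturated chain carbon, two bonds along the chain from an oxygen on a saturated carbon and a triple-bonded carbon. The 1-hydroxy-1-methylethyl group thus becomes 1-hydroxy-1-methylpropyl. Going by the values given here, no two measured compounds differ in one place only, so the data give no direct measure of such a step. The expected step, a 1.1-fold lower number from compound 2 to compound 3 (0.06 log units; within the scatter), is estimated to stay within the scatter in this assay and to show no clear direction. In this assay compound 3 is estimated at 1300 nM (expected range 700 nM to 2400 nM).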

Compound 3, half-maximal inhibitory concentration: 600 nM
For compound 3 the middle estimate is 2.2-fold (0.34 log units) above the measured one, and the stated range ends above it.
By their numbers in this assay, from the lowest: compound 3; then compounds 1 and 2 (each within the scatter of the next).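

In this assay, for the compounds shown here, the change from 1-hydroxy-1-methylethyl to 1-hydroxy-1-methylpropyl gives a 2.5-fold lower number from compound 2 to compound 3 (0.40 log units; beyond the scatter) and is the first step here between compounds that differ in one place only. It shows that this position, on a saturated chain carbon two bonds along the chain from an oxygen on a saturated carbon and a triple-bonded carbon, responds to a single added methyl, with a modest step that lies beyond the scatter. No measurement among these data offers an explanation for the step.

On these data alone, whether a longer chain, such as propyl in place of the added methyl, would lower the number further remains open. So does the outcome with an amine in place of the hydroxyl group on the same chain.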